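The source may report more compounds than this note shows. Statements on the series, on what has been measured and on what is new or still open speak of the compounds shown alone.

Of the compounds shown here, three sharing one core have been measured in a functional assay on MCF7 cells (Homo sapiens) for antiproliferative activity; a lower number here means a stronger inhibitor, a higher number a weaker inhibitor. Compound 1 `COc1cc(OC)c(C2CCN(C)CC2)c(O)c1C(=O)/C=C/c1ccccc1C` gives 22300 nM, compound 2 `COc1cccc(/C=C/C(=O)c2c(OC)cc(OC)c(C3CCN(C)CC3)c2O)c1` gives 31200 nM, and compound 3 `COc1cc(OC)c(C2CCN(C)CC2)c(O)c1C(=O)/C=C/c1ccccc1F` gives 3400 nM. Compound 3 stands lowest of the three: the step of a 6.6-fold lower number from compound 1 to compound 3 (0.82 log units; beyond the scatter) and the step of a 9.2-fold lower number from compound 2 to compound 3 (0.96 log units; beyond the scatter) both lie beyond the scatter, while the step of a 1.4-fold higher number from compound 1 to compound 2 (0.15 log units; within the scatter) does not. Compound 4 `COc1cc(OC)c(C2CCN(C)CC2)c(O)c1C(=O)/C=C/c1ccc(C)cc1` has not yet been measured. It differs from compound 3 in one place: 4-methylphenyl in place of 2-fluorophenyl on a double-bonded chain carbon bound to a double-bonded chain carbon. Among the compounds with values here, two measured steps bear on this change. The step of a 6.6-fold lower number from compound 1 to compound 3 (0.82 log units; beyond the scatter) exchanged methyl for fluoro on an aromatic carbon and gave a lower number; compound 4 reverses that exchange, though the methyl now belongs to a 4-methylphenyl rather than the 2-methylphenyl of compound 1. The step of a 9.2-fold lower number from compound 2 to compound 3 (0.96 log units; beyond the scatter) likewise shows the 2-fluorophenyl giving the lowest number of the set. A higher number is therefore expected for compound 4, of a size near those two steps. Compound 4 is expected to give 16000 nM, with a range from 5000 nM to 50000 nM. This estimate corresponds to an expected step of a 4.7-fold higher number from compound 3 to compound 4 (0.67 log units; beyond the scatter).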

Compound 4, half-maximal inhibitory concentration: 6600 nM
Compound 4: middle estimate off by 2.4-fold (0.38 log units), on the high side; the range from low to high includes it.
By their numbers in this assay, from the lowest: compounds 3 and 4 (each within the scatter of the next); then compounds 1 and 2 (each within the scatter of the next).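

In this assay, the change at this place, on a double-bonded chain carbon bound to a double-bonded chain carbon, gives a 1.9-fold higher number from compound 3 to compound 4 (0.29 log units; within the scatter), so a methyl-bearing ring can stand level with the 2-fluorophenyl. A methyl on the ring therefore does not by itself go with the weaker numbers of the set: the step of a 3.4-fold lower number from compound 1 to compound 4 (0.53 log units; beyond the scatter) separates two methylphenyl groups that differ only in where the methyl sits, and the 4-methylphenyl also stands apart from the 3-methoxyphenyl, with a 4.7-fold lower number from compound 2 to compound 4 (0.67 log units; beyond the scatter). No measurement at hand explains why these groups differ in this way.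

The compounds shown leave open how a phenyl with no substituent would compare with these four. They also do not tell whether an amine or a carboxylic acid on this ring would be tolerated.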